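The compounds below may be only part of what the source reports. "The series", "measured", "known", "first", "only" and "open" are said of these compounds alone.

Measured in a functional assay on the whole organism (strain Wistar albino) for inhibition, with Rattus norvegicus as the target, read by paw edema, with stated times of 30 min and 2 h, at a dose of 20 mg/kg by the oral route; on this read-out higher numbers stand for more inhibition at the one dose given (going by the name of the read-out) and lower numbers for less inhibition:
compound 1 `COc1ccccc1NCC(=O)Oc1ccc2c(C)cc(=O)oc2c1`: 15.3%
compound 2 `Cc1cc(=O)oc2cc(OC(=O)CNc3ccc(Cl)cc3)ccc12`: 23%
compound 3 `Cc1cc(=O)oc2cc(OC(=O)CNc3ccc([N+](=O)[O-])cc3)ccc12`: 17.9%

Compound 2 holds the highest of the three numbers, yet its lead is not secure: the step of a number 7.7 percentage points higher from compound 1 to compound 2 (within the scatter) and the step of a number 5.1 percentage points lower from compound 2 to compound 3 (within the scatter) both lie within the scatter, so the three measured compounds cannot be ordered on these data.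

Compound 4 `Cc1cc(=O)oc2cc(OC(=O)CNN3C=NNC3)ccc12` is not yet measured. It differs from compound 2 by a group of 5 heavy atoms (2 carbon, 3 nitrogen; one five-membered non-aromatic ring with 3 hetero atoms) in place of a group of 7 heavy atoms (6 carbon, 1 chlorine; one six-membered aromatic ring of carbon only), on an amine nitrogen. Neither measured step covers an exchange of this kind: both keep the six-membered aromatic ring of carbon only on the amine nitrogen and vary only what sits on it (4-chlorophenyl for 2-methoxyphenyl, nitro for chloro), and neither moved the read-out beyond the scatter. Going by these compounds, they bear on the new step only by showing that changes at this amine nitrogen have so far stayed small, while the removal of the aromatic ring itself is untested here.

For compound 4 the expected change is therefore a number 6 percentage points lower from compound 2 to compound 4 (within the scatter), with a range wider than the measured steps because the replacement goes beyond what they sample. Compound 4 is estimated to give 17% in this assay, between 6% and 30%.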

Compound 4, a percentage reported as inhibition, in the whole organism at one dose (the size of the read-out at that dose, not a potency): 42.3%
Compound 4: middle estimate off by 25.3 percentage points, on the low side, outside the stated range (above it).
By their numbers in this assay, from the lowest: compounds 1, 3 and 2 (each within the scatter of the next); then compound 4.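

In this assay, the amine nitrogen proves able to move the read-out beyond the scatter once the aromatic ring itself is exchanged, which neither earlier step showed: replacing 4-chlorophenyl with the five-membered non-aromatic ring with 3 hetero atoms gives a number 19.3 percentage points higher from compound 2 to compound 4 (beyond the scatter), and replacing the 2-methoxyphenyl group with the same ring gives a number 27 percentage points higher from compound 1 to compound 4 (beyond the scatter). A six-membered aromatic ring of carbon only on this nitrogen is therefore not required for inhibition at this single dose, and exchanging the whole group has reached further here than the earlier changes that kept that ring. No measurement at hand accounts for the gain.

The exchange alters ring size, aromatic character, hetero atom content and hydrogen-bond donor and acceptor counts all at once, so the shown compounds cannot assign the gain to any one of these features. Going by these compounds, whether a pyridine ring, a piperidine ring or a morpholine ring on the amine nitrogen would keep the gain remains open, as does the behaviour of compound 4 at other doses.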